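The source may hold more compounds than are shown below. What is called first, only, known or untested is meant among the compounds shown, and "the series" means these compounds.

Compound 1 `CCCCS(=O)(=O)Nc1cc(-c2ccc3ncnc(NCCN(C)C)c3c2)cnc1OC`: 280 nM
Compound 2 `COc1ncc(-c2ccc3ncnc(NCCN(C)C)c3c2)cc1NS(C)(=O)=O`: 12600 nM
Compound 3 `COc1ncc(-c2ccc3ncnc(NCCN(C)C)c3c2)cc1NS(=O)(=O)c1ccc(F)cc1`: 9500 nM

In a functional assay on SK-HEP1 cells (Homo sapiens) for antiproliferative activity, read by sulforhodamine B assay, with a stated time of 72 h (on this read-out lower numbers stand for stronger inhibition and higher numbers for weaker inhibition), compound 1 gives 280 nM, the lowest of the three numbers, and its steps to both other compounds lie beyond the scatter. Compound 4 `CCCCS(=O)(=O)Nc1cc(-c2ccc3ncnc(NCc4ccncc4)c3c2)cnc1OC` has not yet been measured. It keeps the butyl sulfonyl group of compound 1 and changes the amine chain: pyridin-4-yl in place of (dimethylamino)methyl on a saturated chain carbon bound to a nitrogen on an aromatic ring. In words, pyridin-4-yl stands in place of (dimethylamino)methyl on a saturated chain carbon bound to a nitrogen on an aromatic ring.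

Among the measured compounds shown here, no measured step touches this place. All three change the group on the sulfonyl sulfur. Two of them are large, a 45-fold higher number from compound 1 to compound 2 (1.65 log units; beyond the scatter) and a 34-fold higher number from compound 1 to compound 3 (1.53 log units; beyond the scatter), while a 1.3-fold lower number from compound 2 to compound 3 (0.12 log units; within the scatter) stays within the scatter. These steps show that the numbers in this assay can move strongly with a single change, but they say nothing direct about the new group. Compound 1 already holds the lowest value, 280 nM, so a moderate rise seems more likely than a fall, though a result with no change is also possible. The expected change is a 2.1-fold higher number from compound 1 to compound 4 (0.33 log units; beyond the scatter), and this is only a loose estimate. For compound 4 the estimated value is 600 nM, with an expected range from 100 nM to 3500 nM.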

Compound 4, half-maximal inhibitory concentration: 8980 nM
The estimate for compound 4 lay 15-fold (1.18 log units) below the measured number, outside the stated range (above it).
By their numbers in this assay, from the lowest: compound 1; then compounds 4, 3 and 2 (each within the scatter of the next).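

In this assay the amine chain on the shared core proves to be a sensitive place: exchanging 2-(dimethylamino)ethyl for (pyridin-4-yl)methyl, with the butyl group on the sulfonyl sulfur kept, gives a 32-fold higher number from compound 1 to compound 4 (1.51 log units; beyond the scatter) as a large step. The earlier compounds shown here changed only the group on the sulfonyl sulfur, where a 34-fold higher number from compound 1 to compound 3 (1.53 log units; beyond the scatter) is a step of similar kind, so they could not show that this second place also moves the number strongly. Nothing measured here gives a reason for the rise.

Only one replacement at this place is shown, so it remains open whether the rise goes with losing the dimethylamino group, with gaining the aromatic ring, or with both, and a 3-(dimethylamino)propyl chain, a 2-(morpholin-4-yl)ethyl chain or a 2-(pyridin-4-yl)ethyl chain could help to separate these possibilities. As far as these compounds go, it also remains open whether the same exchange would have a similar effect with methyl or 4-fluorophenyl on the sulfonyl sulfur in place of butyl.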